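The compounds below may be only part of what the source reports. "The series", "measured", "known", "first", "only" and "open" are said of these compounds alone.

Measured in a functional assay on MCF7 cells (Homo sapiens) for inhibition, read by MTT assay, with a stated time of 2 days; a lower number here means a stronger inhibitor, a higher number a weaker inhibitor:
- compound 1 `Nc1cccc(/C=C/c2ccccc2)c1` gives 14 ug/mL
- compound 2 `Nc1cccc(/C=C/c2cccc(O)c2)c1` gives 54 ug/mL
- compound 3 `COc1cccc(/C=C/c2cccc(O)c2)c1` gives 13 ug/mL

Compound 3 at 13 ug/mL and compound 1 at 14 ug/mL lie within the scatter of each other, while compound 2 stands apart through a 4.2-fold lower number from compound 2 to compound 3 (0.62 log units; beyond the scatter). Compound 4 `COc1cccc(/C=C/c2cccc(N)c2)c1` follows from compound 3 with amino in place of hydroxy on an aromatic carbon. Two modest steps bear on this change: a 3.9-fold higher number from compound 1 to compound 2 (0.59 log units; beyond the scatter), with hydroxy in place of hydrogen, and a 4.2-fold lower number from compound 2 to compound 3 (0.62 log units; beyond the scatter), with methoxy in place of amino. Neither is the same exchange, so no step beyond the scatter is expected in this assay, though a modest one in either direction remains possible. The expected step is a 1.1-fold higher number from compound 3 to compound 4 (0.03 log units; within the scatter). For compound 4 the estimated value is 14 ug/mL, with an expected range of 5 ug/mL to 40 ug/mL.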

Compound 4, half-maximal inhibitory concentration: 34 ug/mL
Estimate against measurement, compound 4: 2.4-fold (0.39 log units) below; low and high end bracket the measured number.
By their numbers in this assay, from the lowest: compounds 3 and 1 (each within the scatter of the next); then compounds 4 and 2 (each within the scatter of the next).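

In this assay, the direct exchange at this place, on an aromatic carbon meta to a large group, gives a 2.6-fold higher number from compound 3 to compound 4 (0.42 log units; beyond the scatter) and so shows that amino and hydroxy are not interchangeable here when methoxy stands on the core. With amino kept, methyl in place of hydrogen on the oxygen gives a 1.6-fold lower number from compound 2 to compound 4 (0.20 log units; within the scatter) while methoxy in place of hydrogen gives a 2.4-fold higher number from compound 1 to compound 4 (0.39 log units; beyond the scatter) as the comparison with the unsubstituted carbon. From the compounds shown here alone, whether a carboxylic acid or a longer alkoxy chain would be tolerated at this place stays open. Nothing available explains these steps.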